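Swapping chloro for methoxy on a long-chain compound

The compounds below may be only part of what the source reports. "The series", "measured", "known", "first", "only" and "open" are said of these compounds alone.

In a functional assay on HCT-116 cells (Homo sapiens) for antiproliferative activity, read by MTT assay, with a stated time of 48 h (on this read-out lower numbers stand for stronger inhibition and higher numbers for weaker inhibition), compound 1 `CCCCC(CCO)n1cnc2c(OC)ncnc21` gives > 50000 nM, which is a limit of the assay and not a number. Compound 2 `CCCCCCCC(CCO)n1cnc2c(OC)ncnc21`, with a longer chain, gives 15300 nM. Compound 3 `CCCCCCCCCCCC(CCO)n1cnc2c(Cl)ncnc21`, with a longer chain still and chloro instead of methoxy, gives 7590 nM, which lies within the scatter of compound 2.

Compound 4 `CCCCCCCCCCCC(CCO)n1cnc2c(OC)ncnc21` keeps the chain of compound 3 and has methoxy in place of chloro on an aromatic carbon. Among the compounds with values here, no measured step isolates this swap. The only one, an at least 3.2-fold lower number from compound 1 to compound 2 (0.51 log units; beyond the scatter), changes the chain while methoxy stays in place, so it shows that a methoxy compound can respond to chain length. Since compound 4 has the long chain and compound 2 already reaches 15300 nM with methoxy and a shorter one, a large change seems unlikely. The expected result is a 1.2-fold higher number from compound 3 to compound 4 (0.07 log units; within the scatter), with no shift beyond the scatter. Compound 4 is estimated at 9000 nM, with an expected range from 3500 nM to 24000 nM.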

Compound 4, half-maximal inhibitory concentration: 8230 nM
Compound 4: the middle estimate sits 1.1-fold (0.04 log units) above what was measured; the range from low to high includes it.
By their numbers in this assay, from the lowest: compounds 3, 4 and 2 (each within the scatter of the next). At a limit, above all of these: compound 1.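

In this assay, methoxy in place of chloro on an aromatic carbon, with the long chain held fixed, gives a 1.1-fold higher number from compound 3 to compound 4 (0.04 log units; within the scatter), so the two groups cannot be told apart at this position on this chain. With methoxy kept, the chain steps differ: butyl in place of hydrogen gives a 1.9-fold lower number from compound 2 to compound 4 (0.27 log units; within the scatter), whereas heptyl in place of hydrogen gives an at least 6.0-fold lower number from compound 1 to compound 4 (0.78 log units; beyond the scatter). Compound 1 stands at a limit of the assay, so the second step is only a lower bound on the size of the change: the limit of > 50000 nM in this assay, at which 1 of the 4 values shown sits.

On these data alone, the swap is seen on the long chain alone, so it stays open whether chloro and methoxy also match on a shorter chain. As far as these compounds go, it is also open whether an amine at this position, or a still longer chain, would move the number beyond the scatter.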